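The compounds below may be only part of what the source reports. "The series", "measured", "known", "first", "only" and "open" are said of these compounds alone.

Of the compounds shown here, three have so far been measured in an assay for inhibition of Polyunsaturated fatty acid 5-lipoxygenase (Homo sapiens), read by HPLC, with stated times of 15 min and 10 min; a higher number here means a weaker inhibitor, a lower number a stronger inhibitor. Compound 1 `Cc1ccc(C(=O)NCc2ccccc2C(F)(F)F)cc1C#CC(C)N(O)C(N)=O` gives 1700 nM. Compound 2 `C[C@H](C#Cc1cccc(C(=O)NCc2ccccc2C(F)(F)F)c1)N(O)C(N)=O` gives 600 nM, and compound 3 `CC(C#Cc1cccc(C(=O)NCc2cccc(F)c2)c1)N(O)C(N)=O` gives 4000 nM. Compound 2 has the lowest number of the three and is the strongest inhibitor among them, since its distances to compound 1 and to compound 3 both lie beyond the usual scatter of this measurement. Compound 4 `CCC(C#Cc1cccc(C(=O)NCc2ccccc2C(F)(F)F)c1)N(O)C(N)=O` has not yet been measured. It differs from compound 2 in a single place: 1-(carbamoyl(hydroxy)amino)propyl in place of 1-(carbamoyl(hydroxy)amino)ethyl on a triple-bonded carbon. Among the measured compounds shown here, no measured pair shows what this change does. A change this small is expected to move the number only a little, so the step of a 1.2-fold higher number from compound 2 to compound 4 (0.07 log units; within the scatter) is expected to stay within the scatter. Compound 4 is estimated at 700 nM, with a range from 300 nM to 1600 nM.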

Compound 4, half-maximal inhibitory concentration: 500 nM
The estimate for compound 4 lay 1.4-fold (0.15 log units) above the measured number; the measured number falls inside the stated range.
By their numbers in this assay, from the lowest: compounds 4 and 2 (each within the scatter of the next); then compound 1; then compound 3.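

In this assay, 1-(carbamoyl(hydroxy)amino)propyl in place of 1-(carbamoyl(hydroxy)amino)ethyl on a triple-bonded carbon gives a 1.2-fold lower number from compound 2 to compound 4 (0.08 log units; within the scatter), so this position takes one more carbon with no change that can be told from the scatter. The swap also loses the defined stereocentre of compound 2, so chain length and stereochemistry cannot be separated in this pair. Nothing available explains the result. Still open, going by these compounds, is whether a longer chain, such as butyl, or a branched isopropyl group would hold the number, and whether the two mirror-image forms of compound 4 differ.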